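The source may report more compounds than this note shows. Statements on the series, on what has been measured and on what is new or still open speak of the compounds shown alone.

Of the compounds shown here, three sharing one core have been measured in a functional assay on CHO cells for antagonist activity at adenosine receptor A2b (Homo sapiens), read by 33P incorporation, with a stated time of 20 min; on this read-out lower numbers stand for stronger inhibition and higher numbers for weaker inhibition. Compound 1 `CCCn1c(-c2ccccc2)nc2c(NC3CCC3)ncnc21` gives 774 nM, compound 2 `CCCn1c(-c2ccccc2)nc2c(NC3CCCCC3)ncnc21` gives 5310 nM, and compound 3 `CCn1c(-c2ccccc2)nc2c(N)ncnc21` gives 3020 nM. Compound 3 thus holds the second highest of the three numbers: its value sits within the scatter of compound 2, while compound 1 lies lower by a margin beyond the scatter. Among the compounds with values here, the only single-point step known, a 6.9-fold higher number from compound 1 to compound 2 (0.84 log units; beyond the scatter), concerns a different position. Compound 4 `CCCn1c(-c2ccccc2)nc2c(N)ncnc21` differs from compound 3 by methyl in place of hydrogen on a saturated chain carbon, two bonds along the chain from an aromatic nitrogen. Within the data shown here, no measured step bears on this change, so no step beyond the scatter is expected in this assay. Compound 4 is therefore estimated at 2000 nM, with a range from 600 nM to 7000 nM. The expected step is a 1.5-fold lower number from compound 3 to compound 4 (0.18 log units; within the scatter).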

Compound 4, inhibition constant: 1040 nM
Compound 4: middle estimate off by 1.9-fold (0.28 log units), on the high side; the measured number falls inside the stated range.
By their numbers in this assay, from the lowest: compounds 1 and 4 (each within the scatter of the next); then compounds 3 and 2 (each within the scatter of the next).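

In this assay, the first step measured at this chain shows that going from ethyl to propyl, methyl in place of hydrogen, is not silent: it gives a 2.9-fold lower number from compound 3 to compound 4 (0.46 log units; beyond the scatter). On a nitrogen on an aromatic ring, hydrogen in place of cyclohexyl gives a 5.1-fold lower number from compound 2 to compound 4 (0.71 log units; beyond the scatter). Hydrogen in place of cyclobutyl gives a 1.3-fold higher number from compound 1 to compound 4 (0.13 log units; within the scatter), so there only cyclohexyl stands apart from hydrogen.

Nothing measured gives a reason for these steps. On these data alone, whether a butyl chain would extend the ethyl-to-propyl step remains open.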